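A few compounds are considered here, and "the series" means these few. Any claim that something is new, unique, unknown or untested is made for them only; others in the source may bear on it.

Compound 1 `CC(=O)OC(C)n1cnc2c(Cl)nc(N)nc21` — in a functional assay on HT-29 cells (Homo sapiens) for inhibition (a lower number here means a stronger inhibitor, a higher number a weaker inhibitor), compound 1 gives a value that is a limit of the assay, > 500000 nM.
Compound 2 `CC(=O)OC(C)n1cnc2c(Cl)nc(F)nc21` — in this assay compound 2 gives 75900 nM.
Compound 3 `CC(=O)OC(C)n1cnc2c(S)nc(N)nc21` — in this assay compound 3 gives a value that is a limit of the assay, > 500000 nM.

Compound 3 therefore has no number of its own in this assay; it sits at the limit of > 500000 nM in this assay, at which 2 of the 3 values shown sit, and compound 1 sits there as well. The step from compound 1 to compound 3, the exchange of chloro for sulfanyl, is thus a step that the two limits leave unreadable from compound 1 to compound 3.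

Compound 4 `CC(=O)OC(C)n1cnc2c(S)nc(F)nc21` has not been measured in this assay. It differs from compound 3 in one place: fluoro in place of amino on an aromatic carbon. The same change has been measured once, on the chloro core, where it gave an at least 6.5-fold lower number from compound 1 to compound 2 (0.81 log units; beyond the scatter). That step starts from a limit, so only its lower bound is known; the exchange of amino for fluoro at this position is at least modestly favourable there. Carried over to compound 3, which also starts from a limit, the step from compound 3 to compound 4 is expected to be an at least 3.3-fold lower number from compound 3 to compound 4 (0.52 log units; beyond the scatter), leading into the measurable range but staying weak. Compound 4 is estimated at 150000 nM, with a range from 30000 nM to 600000 nM.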

Compound 4, half-maximal inhibitory concentration: > 500000 nM
Compound 4: a limit, no number; the forecaster's own chance of this, stated with the estimate: 35%; middle value at least 3.3-fold (0.52 log units) from the limit.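

The exchange of chloro for sulfanyl, unreadable with amino present, can now be read with fluoro present: in this assay it gives an at least 6.5-fold higher number from compound 2 to compound 4 (0.81 log units; beyond the scatter). The fluoro-for-amino change therefore does not yield a measurable number with sulfanyl present as it did with chloro present, although the step from compound 3 to compound 4 cannot be read because both ends are limits, and a gain too small to reach the measurable range remains possible. Compound 4 joins compound 1 and compound 3 at one limit of the assay, leaving compound 2, which carries chloro and fluoro together, as the only compound here with a number of its own: the limit of > 500000 nM in this assay, at which 3 of the 4 values shown sit.

On these data alone, how far compound 1, compound 3 and compound 4 lie past that limit remains open, so the size of the fluoro-for-amino change with sulfanyl present is unknown. As far as these compounds go, it is also open whether a bromo or methylthio group in place of the chloro, or a methoxy group in place of the fluoro, would keep a readable value.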